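The source may hold more compounds than are shown below. What is called first, only, known or untested is meant among the compounds shown, and "the series" means these compounds.

Measured compounds in a functional assay on SW-620 cells (Homo sapiens), read by MTT assay, with a stated time of 72 h; on this read-out lower numbers stand for stronger inhibition and higher numbers for weaker inhibition:
- compound 1 `COc1cc(NC(C)CCCNC(=O)NCc2ccncc2)c2ncccc2c1`: 2000 nM
- compound 2 `COc1cc(NC(C)CCCNC(=O)NCc2ccccc2)c2ncccc2c1`: 9000 nM
- compound 3 `COc1cc(NC(C)CCCNC(=O)NC2CCCC2)c2ncccc2c1`: 19000 nM

Compound 3 carries the highest number of the three, with compound 2 nearest and compound 1 furthest away. The steps that lead to compound 3 were a 9.5-fold higher number from compound 1 to compound 3 (0.98 log units; beyond the scatter) and a 2.1-fold higher number from compound 2 to compound 3 (0.32 log units; beyond the scatter); the step between the two substituted benzylic groups was a 4.5-fold higher number from compound 1 to compound 2 (0.65 log units; beyond the scatter).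

Compound 4 `COc1cc(NC(C)CCCNC(=O)NCC2CCCCC2)c2ncccc2c1` differs from compound 3 in one place: cyclohexylmethyl in place of cyclopentyl on an amide-type nitrogen. The entering group brings back a ring attached through a chain carbon, as in compound 2, but as a six-membered non-aromatic ring of carbon only rather than phenyl. Among the compounds with values here, the nearest measured step is the one from compound 2 to compound 3, which was modest; the present change partly reverses it, so a modest movement back toward the number of compound 2, or none beyond the scatter, is expected, giving an expected step of a 1.6-fold lower number from compound 3 to compound 4 (0.20 log units; within the scatter). Compound 4 is therefore estimated at 12000 nM, with a range from 5000 nM to 30000 nM.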

Compound 4, half-maximal inhibitory concentration: 61000 nM
For compound 4 the middle estimate is 5.1-fold (0.71 log units) below the measured one; measured number outside the range, above it.
By their numbers in this assay, from the lowest: compound 1; then compound 2; then compound 3; then compound 4.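

In this assay a saturated ring reached through a chain carbon does not bring the number back toward that of compound 2: cyclohexylmethyl in place of cyclopentyl on the amide-type nitrogen gives a 3.2-fold higher number from compound 3 to compound 4 (0.51 log units; beyond the scatter) and leaves compound 4 highest of the series. Within the data shown here, the kind of ring counts at this position, with phenyl to cyclohexyl giving a 6.8-fold higher number from compound 2 to compound 4 (0.83 log units; beyond the scatter) and pyridin-4-yl to cyclohexyl giving a 31-fold higher number from compound 1 to compound 4 (1.48 log units; beyond the scatter) as the only large step so far, and both compounds with an aromatic ring carry lower numbers than both with a saturated ring. Nothing at hand explains the size of these steps.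

From the compounds shown here alone, the step to compound 4 changes ring size and adds a chain carbon together, so the share of each stays open. Cyclohexyl directly on the nitrogen, or cyclopentylmethyl, would separate the two, and pyridin-3-yl would test the place of the ring nitrogen.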